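Working notes: the step from compound 3 to compound 4

This account rests on a few compounds, and the source may have more. Where it says the series, first, only, none or still open, it means among the compounds named here.

- compound 1 `COc1cc(-n2c(-c3ccc(O)cc3)c[nH]c2=O)cc(OC)c1OC` gives > 50000 nM in a functional assay on K-562R cells (Homo sapiens) for cytotoxicity, read by MTT assay, with a stated time of 48 h; on this read-out higher numbers stand for weaker inhibition and lower numbers for stronger inhibition
- compound 2 `COc1ccc(-c2c[nH]c(=O)n2-c2cc(OC)c(OC)c(OC)c2)cc1OC` gives > 50000 nM in this assay
- compound 3 `COc1cc(NC(=O)n2cc(-c3ccc(O)cc3)n(-c3cc(OC)c(OC)c(OC)c3)c2=O)cc(OC)c1OC` gives > 50000 nM in this assay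

Each of these values is a limit of the assay and not a number. Compound 3 stands with the other two (the limit of > 50000 nM in this assay, at which 3 of the 3 values shown sit) and offers no number to start from. Compound 4 `COc1ccc(-c2cn(C(=O)Nc3cc(OC)c(OC)c(OC)c3)c(=O)n2-c2cc(OC)c(OC)c(OC)c2)cc1O` carries 3-hydroxy-4-methoxyphenyl in place of 4-hydroxyphenyl on an aromatic carbon, next to the ring atom that bears a 3,4,5-trimethoxyphenyl group (3-hydroxy-4-methoxyphenyl in place of 4-hydroxyphenyl on an aromatic carbon). Among the compounds with values here, no measured step gives a guide to size. In this assay a move towards stronger inhibition is expected, though a result again at the limit remains quite possible. The expected size is an at least 3.3-fold lower number from compound 3 to compound 4 (0.52 log units; beyond the scatter) in that direction, an estimate only. The estimate for compound 4 is 15000 nM as the expected middle, with 800 nM to 50000 nM as its expected range.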

Compound 4, half-maximal inhibitory concentration: > 50000 nM
Compound 4: no number, only a limit; the forecaster's own chance of this, stated with the estimate: 45%; middle value at least 3.3-fold (0.52 log units) from the limit.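

No step can be read from compound 3 to compound 4, since each gives only a limit and not a number: the limit of > 50000 nM in this assay, at which 4 of the 4 values shown sit.

In this assay the compounds shown leave open whether any change on the shared core gives a number rather than a limit.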